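The source may hold more compounds than are shown below. What is called first, only, known or untested is meant among the compounds shown, and "the series" means these compounds.

Three compounds set the scene. Compound 1 `O=S(=O)(Nc1ccc(CNc2nc(NC3CC3)nc3ccccc23)cc1)c1ccc(F)cc1` gives 4100 nM in a functional assay on SW480 cells (Homo sapiens) for inhibition, read by luminescence and resazurin assay, with a stated time of 3 days; a lower number here means a stronger inhibitor, a higher number a weaker inhibitor. Compound 2 `CCNc1nc(NCc2ccc(NC(=O)c3ccc(F)cc3)cc2Cl)c2ccccc2n1` gives 1600 nM in the same assay, and compound 3 `O=C(Nc1ccc(F)cc1)c1ccc(CNc2nc(NC3CC3)nc3ccccc23)cc1` gives 2600 nM. Compound 3 thus stands second highest of the three numbers, with compound 1 nearest to it and compound 2 furthest, both within the scatter of it. For the measured compounds named here, the one clean step among them, a 1.6-fold lower number from compound 1 to compound 3 (0.20 log units; within the scatter), concerns the other end of the molecule, where the (4-fluorophenyl)carbamoyl group replaced the ((4-fluorophenyl)sulfonyl)amino group, and it stayed within the scatter.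

Compound 4 `CC1CN(c2nc(NCc3ccc(C(=O)Nc4ccc(F)cc4)cc3)c3ccccc3n2)CCN1` is the next one to be measured. It differs from compound 3 in a single place: 3-methylpiperazin-1-yl in place of cyclopropylamino on an aromatic carbon, on the aromatic carbon between two ring nitrogen atoms of the shared core. Going by the values given here, no measured step touches this position; compound 2 carries an ethylamino group there but also differs elsewhere, and its value and that of compound 3 sit within the scatter of each other. With nothing in the data pointing either way, compound 4 is expected to show a step of a 1.0-fold lower number from compound 3 to compound 4 (0.02 log units; within the scatter) relative to compound 3, that is, no change beyond the scatter. Compound 4 is therefore estimated at 2500 nM, within a range of 800 nM to 8000 nM.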

Compound 4, half-maximal inhibitory concentration: 3200 nM
Estimate against measurement, compound 4: 1.3-fold (0.11 log units) below, and the stated range covers the measured number.
By their numbers in this assay, from the lowest: compounds 2, 3, 4 and 1 (each within the scatter of the next, the first and the last beyond it).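

In this assay, the aromatic carbon between two ring nitrogen atoms now has a measured step of its own: 3-methylpiperazin-1-yl in place of cyclopropylamino gives a 1.2-fold higher number from compound 3 to compound 4 (0.09 log units; within the scatter) and so leaves the number within the scatter. The entering group has 7 heavy atoms against 4 for the group that leaves, a six-membered non-aromatic ring with 2 hetero atoms in place of a three-membered carbon ring, and this pair shows that so large a change in the group at this position need not move the number beyond the scatter. For the compounds shown here, nothing available explains this tolerance in the single pair, and no supporting measurement bears on the result.

From the compounds shown here alone, whether morpholin-4-yl, the piperazin-1-yl group without its methyl, or a longer chain ending in a dimethylamino group would shift the number beyond the scatter remains open. Going by these compounds, it also remains open whether the same exchange would behave alike with the ((4-fluorophenyl)sulfonyl)amino group of compound 1 at the other end of the molecule, since this one pair carries only the (4-fluorophenyl)carbamoyl group.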